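A few compounds are considered here, and "the series" means these few. Any claim that something is new, unique, unknown or untested is made for them only; others in the source may bear on it.

Compound 2 `COc1cc(-c2nn(-c3cccc(NC(=O)Nc4ccc(Cl)c(Cl)c4)c3)cc2-c2ccncc2)ccc1Cl` gives 859 nM in a functional assay on RXF 393 cells (Homo sapiens) for inhibition, read by sulforhodamine B assay, with a stated time of 48 h (a lower number here means a stronger inhibitor of growth, a higher number a weaker inhibitor of growth), the lowest of the three numbers seen so far, although compound 1 `COc1cc(-c2nn(-c3cccc(NC(=O)Nc4cc(C(F)(F)F)cc(C(F)(F)F)c4)c3)cc2-c2ccncc2)ccc1Cl` with 869 nM and compound 3 `O=C(Nc1cccc(-n2cc(-c3ccncc3)c(-c3ccc(Cl)c(O)c3)n2)c1)Nc1ccc(Cl)c(Cl)c1` with 1000 nM both sit within the scatter of that value. For the measured compounds named here, the only measured step that changes a single place, a 1.2-fold higher number from compound 2 to compound 3 (0.07 log units; within the scatter), also stays within the scatter, so nothing so far separates the three compounds. Compound 4 `COc1cc(-c2nn(-c3cccc(NC(=O)c4ccccc4)c3)cc2-c2ccncc2)ccc1Cl` differs from compound 2 by phenyl in place of (3,4-dichlorophenyl)amino on a carbonyl carbon. Going by the values given here, no measured step covers a change of this kind, so the expectation rests on the change itself; a weaker inhibitor, hence a higher number, is expected. The estimated step is a 3.5-fold higher number from compound 2 to compound 4 (0.54 log units; beyond the scatter). Compound 4 is therefore expected to give about 3000 nM, with a likely range from 1000 nM to 10000 nM.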

Compound 4, concentration for 50% growth inhibition: 646 nM
The estimate for compound 4 lay 4.6-fold (0.67 log units) above the measured number; the measured number lies below the stated range.
By their numbers in this assay, from the lowest: compounds 4, 2, 1 and 3 (each within the scatter of the next).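

In this assay, a 1.3-fold lower number from compound 2 to compound 4 (0.12 log units; within the scatter) shows that this large change on the carbonyl carbon leaves the number within the scatter. The amino link and both chlorine atoms of the (3,4-dichlorophenyl)amino group can therefore be lost in compound 4 without any measurable loss of growth inhibition. Nothing available explains why so large a change has so little effect. Still open, as far as these compounds go, is whether an amine or a carboxylic acid on the phenyl ring of compound 4 would move the number beyond the scatter.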